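The compounds below may be only part of what the source reports. "The series", "measured", "known", "first", "only" and "open" are said of these compounds alone.

Measured compounds:
Compound 1, `CCC(=O)Nc1c(C(O)(C(F)(F)F)C(F)(F)F)ccc2ccccc12`, 15 nM
Compound 2, `O=C(Nc1c(C(O)(C(F)(F)F)C(F)(F)F)ccc2ccccc12)c1ccccc1`, 44 nM
Compound 3, `O=C(Nc1c(C(O)(C(F)(F)F)C(F)(F)F)ccc2ccccc12)c1cccc([N+](=O)[O-])c1`, 117 nM

All three were tested in an assay on LtK cells with ATP-sensitive inward rectifier potassium channel 11 (Homo sapiens) as the target; on this read-out lower numbers stand for an effect already at smaller amounts and higher numbers for an effect only at larger amounts of compound. Compound 3 stands at the highest number of the three; compound 2 is nearest to it and compound 1 furthest. The three steps among them are a 2.9-fold higher number from compound 1 to compound 2 (0.47 log units; beyond the scatter), a 7.8-fold higher number from compound 1 to compound 3 (0.89 log units; beyond the scatter) and a 2.7-fold higher number from compound 2 to compound 3 (0.42 log units; beyond the scatter).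

Compound 4 is `O=C(Nc1c(C(O)(C(F)(F)F)C(F)(F)F)ccc2ccccc12)c1ccc(I)cc1`. It differs from compound 3 in one place: 4-iodophenyl in place of 3-nitrophenyl on a carbonyl carbon. Two things happen at once here. The nitro group leaves, and the step of a 2.7-fold higher number from compound 2 to compound 3 (0.42 log units; beyond the scatter) shows what that group had added on top of the plain phenyl of compound 2. In the other direction, iodine enters on the phenyl ring, and no measured pair among these compounds carries iodine, so that part of the change has no step to lean on.

The expectation is therefore anchored on compound 2, which gives 44 nM in this assay, with a widened range to allow for the iodine. Compound 4 is estimated at 50 nM, between 18 nM and 140 nM. This estimate amounts to the expected step of a 2.3-fold lower number from compound 3 to compound 4 (0.37 log units; beyond the scatter), a modest move toward a lower number.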

Compound 4, half-maximal effective concentration: 154 nM
Estimate against measurement, compound 4: 3.1-fold (0.49 log units) below, and the stated range ends below it.
By their numbers in this assay, from the lowest: compound 1; then compound 2; then compounds 3 and 4 (each within the scatter of the next).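

In this assay, 4-iodophenyl in place of 3-nitrophenyl on the carbonyl carbon changes little, with a 1.3-fold higher number from compound 3 to compound 4 (0.12 log units; within the scatter), so losing the nitro group does not by itself bring the number back to that of the plain phenyl of compound 2. Adding iodine to the plain phenyl ring goes with a 3.5-fold higher number from compound 2 to compound 4 (0.54 log units; beyond the scatter), which means that two quite different groups on the phenyl ring, nitro and iodo, each go with a higher number than the unsubstituted ring, and that across these four compounds substitution on the phenyl never lowers the number. With a 10-fold higher number from compound 1 to compound 4 (1.01 log units; beyond the scatter), the change from ethyl to an aromatic ring on the carbonyl carbon now reaches a large step, though nothing shown accounts for why these two groups end up so alike.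

The names 3-nitrophenyl and 4-iodophenyl differ in both the group and its place on the ring, so the effects of the two cannot be separated here. On these data alone, it also stays open whether a longer chain such as butyl in place of ethyl, or an amine or a carboxylic acid on the phenyl ring, would follow the same trend.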